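Tetrazole for Triazole on the Sulfur Linker

A few compounds are considered here, and "the series" means these few. Any claim that something is new, unique, unknown or untested is made for them only; others in the source may bear on it.

Measured compounds:
Compound 1, `Cc1ccc(-c2cs/c(=N/NC(=O)CSc3nnnn3-c3ccccc3)n2-c2ccccc2)cc1`, 55.1%
Compound 2, `Cc1ccc(-c2cs/c(=N/NC(=O)CSc3nncn3C)n2-c2ccccc2)cc1`, 72%
Compound 3, `Cn1cnnc1SCC(=O)N/N=c1/scc(-c2ccccc2)n1-c1ccccc1`, 79.6%

Three compounds were tested in a functional assay on C6 cells (Rattus norvegicus) for cytotoxicity, read by MTT assay, with a stated time of 24 h, tested at 12 ug/mL; on this read-out higher numbers stand for a weaker effect at the one concentration tested and lower numbers for a stronger effect. Compound 3 stands highest of the three, but its gap to compound 2 is within the scatter, so no order between those two can be claimed; only compound 1 lies beyond the scatter from it.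

Two single changes connect the measured compounds. The change 1-phenyl-1H-tetrazol-5-yl in place of 4-methyl-4H-1,2,4-triazol-3-yl on a sulfur gave a number 16.9 percentage points lower from compound 2 to compound 1 (beyond the scatter). The two cores differ by hydrogen in place of methyl on an aromatic carbon, which gave a number 7.6 percentage points higher from compound 2 to compound 3 (within the scatter).

Compound 4, `O=C(CSc1nnnn1-c1ccccc1)N/N=c1/scc(-c2ccccc2)n1-c1ccccc1`, has not yet been measured in this assay. It differs from compound 3 by 1-phenyl-1H-tetrazol-5-yl in place of 4-methyl-4H-1,2,4-triazol-3-yl on a sulfur. This is the same change as from compound 2 to compound 1, made on the other core; the place is described in the same words in both cases, so it is taken as the same change. That earlier step lowered the read-out by a modest amount beyond the scatter. Going by the values given here, on the strength of that one example, the step from compound 3 to compound 4 is expected to be of similar size, a number 17.6 percentage points lower from compound 3 to compound 4 (beyond the scatter), resting only on the single measured pair. Compound 4 is therefore estimated at 62%, with a likely range from 50% to 74%.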

Compound 4, a percentage reported as activity, at one concentration (the size of the read-out at that concentration, not a potency): 47.1%
Compound 4: the middle estimate sits 14.9 percentage points above what was measured; measured number below the stated range.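

In this assay, going by these compounds alone, 1-phenyl-1H-tetrazol-5-yl in place of 4-methyl-4H-1,2,4-triazol-3-yl on a sulfur again lowered the read-out, giving a number 32.5 percentage points lower from compound 3 to compound 4 (beyond the scatter), so the direction of the change carried over to the second core but its size did not: the same change on two cores in this assay, a number 16.9 percentage points lower (beyond the scatter) from compound 2 to compound 1 and a number 32.5 percentage points lower (beyond the scatter) from compound 3 to compound 4, 15.6 percentage points apart, beyond the scatter of two such steps Read the other way around the same four compounds, hydrogen in place of methyl on an aromatic carbon gave a number 8 percentage points lower from compound 1 to compound 4 (within the scatter), and although neither this step nor its counterpart lies beyond the scatter on its own, the two still differ from each other: the same change on two cores in this assay, a number 7.6 percentage points higher (within the scatter) from compound 2 to compound 3 and a number 8 percentage points lower (within the scatter) from compound 1 to compound 4, 15.6 percentage points apart, beyond the scatter of two such steps This shows that the effect of the change depends on the core in this small set, but it rests on only two cores and a single concentration, and it does not show why the size differs or what size to expect on a further core.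

The compounds shown leave open whether the lower read-out follows the tetrazole ring or the phenyl ring, as both enter in a single step. They also leave open how an amine or a carboxylic acid in place of the methyl on the aromatic carbon of the core would behave with either group on the sulfur.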